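A few compounds are considered here, and "the series" means these few. Any claim that something is new, unique, unknown or untested is made for them only; others in the source may bear on it.

Of the compounds shown here, two in this set have so far been measured in an assay on isolated protein for inhibition of matrix metalloproteinase-9 (Homo sapiens), read by fluorescence, with a stated time of 30 min; on this read-out lower numbers stand for stronger inhibition and higher numbers for weaker inhibition. Compound 1 `COc1ccc(S(=O)(=O)N(CCn2cc(CCCCOc3cccnc3F)nn2)[C@@H](C(=O)NO)C(C)C)cc1` gives 0.3 nM, and compound 2 `Cc1ccc(S(=O)(=O)N(CCn2cc(CCCF)nn2)[C@@H](C(=O)NO)C(C)C)cc1` gives 3 nM. Compound 2 therefore has the higher of the two numbers, that is the weaker inhibition, and the gap between it and compound 1 is beyond the scatter of repeated measurements.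

Compound 3 `Cc1ccc(S(=O)(=O)N(CCn2cc(CCCCOc3cccnc3F)nn2)[C@@H](C(=O)NO)C(C)C)cc1` has not yet been measured. It is built from compound 2 by a single change: ((2-fluoropyridin-3-yl)oxy)methyl in place of fluoro on a saturated chain carbon, three bonds along the chain from an aromatic carbon. After this change compound 3 carries the same extended chain ending in the fluoropyridinyloxy group that compound 1 carries, so the only remaining difference between compound 3 and compound 1 lies in one small group on the shared core.

Since compound 1 with that same chain gives 0.3 nM, compound 3 is expected to move toward it, and the step of a 5.0-fold lower number from compound 2 to compound 3 (0.70 log units; beyond the scatter) is expected to be a drop well beyond the scatter. The estimate for compound 3 in this assay is 0.6 nM, with a range from 0.2 nM to 2 nM.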

Compound 3, half-maximal inhibitory concentration: 6 nM
Compound 3: the middle estimate sits 10-fold (1.00 log units) below what was measured; the whole stated range lies below it.
By their numbers in this assay, from the lowest: compound 1; then compounds 2 and 3 (each within the scatter of the next).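

In this assay, putting ((2-fluoropyridin-3-yl)oxy)methyl in place of fluoro on the saturated chain carbon gives a 2.0-fold higher number from compound 2 to compound 3 (0.30 log units; within the scatter) and so, with methyl on the aromatic carbon of the shared core, this far bigger chain end with its added ring leaves the number within the usual scatter. The change at the other end of the molecule, methyl in place of methoxy on an aromatic carbon, gives a 20-fold higher number from compound 1 to compound 3 (1.30 log units; beyond the scatter) and is a large step, which shows that with this long chain in place, the low number of compound 1 depends on its methoxy group and is not carried by the chain end alone. Nothing measured here explains why a change of one small group counts for so much while the much bigger chain change does not.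

The compounds shown leave open whether methoxy in place of methyl would lower the number on the short fluorinated chain of compound 2 as it does on the long chain. They also leave open how other groups would behave, such as ethoxy or chloro on that aromatic carbon, or an amine or a carboxylic acid at the chain end.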